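Bromo replacing hydrogen on the core of compound 1

This account rests on a few compounds, and the source may have more. Where it says the series, first, only, none or still open, it means among the compounds named here.

Three members of the series have numbers in an assay on isolated protein for inhibition of coagulation factor XII (Homo sapiens); on this read-out lower numbers stand for stronger inhibition and higher numbers for weaker inhibition. Compound 1 `O=C(Nc1ccccc1)c1cc2ccccc2oc1=O` gives 42000 nM, the highest of the three. Going by the values given here, compound 2 `Cc1ccc2oc(=O)c(C(=O)Nc3cnc4ccccc4c3)cc2c1` gives 8300 nM, and compound 3 `Cc1cccc(NC(=O)c2cc3cc(C)ccc3oc2=O)c1` gives 10000 nM; both of these lie beyond the scatter from compound 1, which thus stands as the weakest of the three so far. Among the compounds with values here, compounds 2 and 3 each carry a methyl on the shared core and differ from compound 1 in the amide part as well, so no single-change step among the measured compounds can be drawn.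

Compound 4 `O=C(Nc1ccccc1)c1cc2cc(Br)ccc2oc1=O` has not been measured. It differs from compound 1 by bromo in place of hydrogen on an aromatic carbon. Compound 1 is expected to be the starting point for a moderate step to compound 4, estimated as a 2.8-fold lower number from compound 1 to compound 4 (0.45 log units; beyond the scatter) toward a lower number, given that compound 2, which carries a methyl on the shared core, gives 8300 nM and compound 3, which also carries a methyl on the shared core, gives 10000 nM. The number expected for compound 4 is 15000 nM, within a range from 5000 nM to 45000 nM.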

Compound 4, half-maximal inhibitory concentration: 24000 nM
Compound 4: middle estimate off by 1.6-fold (0.20 log units), on the low side, within the range that was stated.
By their numbers in this assay, from the lowest: compounds 2 and 3 (each within the scatter of the next); then compounds 4 and 1 (each within the scatter of the next).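

Going by these compounds alone, compound 4 gives the first single-change step, and in this assay that step (a 1.8-fold lower number from compound 1 to compound 4 (0.24 log units; within the scatter)) stays within the scatter. Bromo in place of hydrogen on this aromatic carbon, meta to a fused ring and para to a fused ring, therefore gives no readable difference with the unsubstituted phenyl amide of compound 1 held constant. This is something compounds 2 and 3 could not show, as each differs from compound 1 in both the shared core and the amide part. No measured information bears on why this replacement leaves the number within the scatter.

Within the data shown here, the separate contributions of the methyl and the amide part to the values of compounds 2 and 3 remain unresolved, with no single-change pair isolating either. On these data alone, whether an amine or a carboxylic acid on this aromatic carbon would move the number beyond the scatter also stays open.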